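A few compounds are considered here, and "the series" means these few. Any claim that something is new, unique, unknown or untested is made for them only; others in the source may bear on it.

Series notes. Going by the values given here, in a functional assay on HEK293 cells for positive allosteric modulation of metabotropic glutamate receptor 5 (Rattus norvegicus), read by fluorescence and calcium flux (on this read-out lower numbers stand for smaller maximal responses and higher numbers for larger maximal responses), compound 2 `CC(C)(C)CNC(=O)c1ccc(C#Cc2cccc(F)c2)cn1` gives 63.9%, one of only two numbers so far; compound 1 `C[C@@H](NC(=O)c1ccc(C#Cc2ccc(F)cc2F)cn1)C(C)(C)O` gives 61.2% in this assay, a value that sits within the scatter of compound 2, so the two cannot be told apart. Among the compounds with values here, no single-change pair between measured compounds exists to anchor the next step. Compound 3 `CC1(CNC(=O)c2ccc(C#Cc3cccc(F)c3)cn2)COC1` keeps the core of compound 2 with 3-methyloxetan-3-yl in place of tert-butyl on a saturated chain carbon bound to an amide-type nitrogen. For this change, the step from compound 2 to compound 3 is expected to be small and no larger than the scatter, reading a number 5.9 percentage points lower from compound 2 to compound 3 (within the scatter). Compound 3 is estimated at 58%, with a range from 40% to 76%.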

Compound 3, largest response reached (reported as efficacy), in percent of the reference or control that the assay uses: 60.4%
Beside the measured number, compound 3's estimate is 2.4 percentage points below it; the range from low to high includes it.
By their numbers in this assay, from the lowest: compounds 3, 1 and 2 (each within the scatter of the next).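

In this assay the series gains its first single-change pair, reading a number 3.5 percentage points lower from compound 2 to compound 3 (within the scatter), so on a saturated chain carbon bound to an amide-type nitrogen, 3-methyloxetan-3-yl and tert-butyl cannot be told apart. The entering four-membered ring and its hydrogen-bond acceptor bring no step beyond the scatter. No evidence on the reason for this is at hand.

Going by these compounds, whether a primary amine, a carboxylic acid or a longer chain at this place would hold the maximal response remains open. On these data alone, the same exchange on another core also remains open.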